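This account rests on a few compounds, and the source may have more. Where it says the series, first, only, none or still open, it means among the compounds named here.

Measured so far in a functional assay on the whole organism with Rattus norvegicus as the target; a lower number here means that less compound is needed, a higher number that more compound is needed for the effect:
- compound 1 `CCOC(=O)C(=O)Nc1cccc(C)c1C#N` gives 4.6 mg/kg
- compound 2 `CCOC(=O)C(=O)Nc1cccc([N+](=O)[O-])c1C#N` gives 82 mg/kg

Among the measured compounds shown here, compound 2 holds the higher of the two numbers, and its only neighbour is compound 1. The next structure is compound 3 `CCOC(=O)C(=O)Nc1cccc(C(=O)OC)c1C#N`, which carries this change from compound 2: methoxycarbonyl in place of nitro on an aromatic carbon. In words, methoxycarbonyl takes the place of nitro on an aromatic carbon, ortho to a cyano group.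

For the measured compounds named here, one measured step bears on this position: an 18-fold higher number from compound 1 to compound 2 (1.25 log units; beyond the scatter), large and beyond the scatter, with nitro in place of methyl on an aromatic carbon. It shows that this assay responds strongly to the group at this carbon. Going by the values given here, no measurement yet places methoxycarbonyl relative to methyl or nitro. Since compound 2 sits at the top of the range with 82 mg/kg, a move down is judged more likely than a further rise, though smaller than the measured step.

The expected change is a 2.7-fold lower number from compound 2 to compound 3 (0.44 log units; beyond the scatter). For compound 3 the estimated value is 30 mg/kg, with an expected range from 7 mg/kg to 120 mg/kg.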

Compound 3, dose for half-maximal effect: 0.8 mg/kg
For compound 3 the middle estimate is 38-fold (1.57 log units) above the measured one; the whole stated range lies above it.
By their numbers in this assay, from the lowest: compound 3; then compound 1; then compound 2.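

At this carbon the series is far more sensitive than the methyl-to-nitro comparison alone could show: in this assay, methoxycarbonyl in place of nitro gives a large step (a 100-fold lower number from compound 2 to compound 3 (2.01 log units; beyond the scatter)), and the direction is opposite to that of the earlier change (an 18-fold higher number from compound 1 to compound 2 (1.25 log units; beyond the scatter)). Methoxycarbonyl also improves on methyl, although more modestly (a 5.8-fold lower number from compound 1 to compound 3 (0.76 log units; beyond the scatter)), so methyl no longer marks the low end of the range and the order from the lowest number is methoxycarbonyl, methyl, nitro, with every step beyond the scatter. Nitro and methoxycarbonyl have the same counts of hydrogen-bond donors, hydrogen-bond acceptors and double bonds outside aromatic rings, and neither carries a net charge, yet they lie at opposite ends of this range, so these counts do not sort the three compounds.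

On these data alone, it remains open whether the low number persists with a carboxylic acid, a primary amide or an ethyl ester at this carbon. No measured property in hand accounts for the separation between nitro and methoxycarbonyl.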